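The source may hold more compounds than are shown below. What is called first, only, known or untested is meant among the compounds shown, and "the series" means these compounds.

In a functional assay on MDA-MB-231 cells (Homo sapiens) for antiproliferative activity, read by MTT assay, with a stated time of 48 h (on this read-out higher numbers stand for weaker inhibition and lower numbers for stronger inhibition), compound 1 `CCOC(=O)CN(Cc1ccccc1)c1nc(NCc2ccccc2)ncc1[N+](=O)[O-]` gives 82400 nM. For the measured compounds named here, that is the only plain number in this set, so compound 1 stands alone as a weak inhibitor with nothing measured beside it to rank it against. Compound 2 `COC(=O)CN(C)c1nc(Nc2ccccc2)ncc1[N+](=O)[O-]` returns only a limit, > 100000 nM, in this assay, and the limit of > 100000 nM in this assay, at which 1 of the 2 values shown sits, shows where that limit sits. Going by the values given here, no pair of measured compounds differing in one place is available, so the size of the change to compound 3 cannot be read from a measured step. Compound 3 `CCOC(=O)CNc1ncc([N+](=O)[O-])c(N(CC(=O)OCC)Cc2ccccc2)n1` differs from compound 1 by ethoxycarbonyl in place of phenyl on a saturated chain carbon bound to a nitrogen on an aromatic ring. Since compound 1 already stands at 82400 nM in this assay, the expected step from compound 1 to compound 3 is a 1.8-fold higher number from compound 1 to compound 3 (0.26 log units; within the scatter), a mild weakening rather than a gain. The estimate for compound 3 in this assay is 150000 nM, expected to fall between 60000 nM and 400000 nM, with a real chance that only a limit is reported.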

Compound 3, half-maximal inhibitory concentration: 92500 nM
Estimate against measurement, compound 3: 1.6-fold (0.21 log units) above, and the stated range covers the measured number.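

In this assay, putting ethoxycarbonyl in place of phenyl on a saturated chain carbon bound to a nitrogen on an aromatic ring gives a 1.1-fold higher number from compound 1 to compound 3 (0.05 log units; within the scatter). For the compounds shown here, this is the first measured step in the set, and it shows that an aromatic ring at this place is not needed to keep the weak activity of compound 1, since the two compounds cannot be told apart. Compound 2 still gives no plain number, only a limit of the assay: the limit of > 100000 nM in this assay, at which 1 of the 3 values shown sits.

On these data alone, whether a carboxylic acid, an amine or a longer chain at this place would move the number beyond the usual scatter remains open. Also open, as far as these compounds go, is whether any group here can lift this series out of the weak range, since this one step shows only a swap that leaves the activity where it was.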